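A Cyclopropylmethylsulfanyl Analogue of Compound 1

A few compounds are considered here, and "the series" means these few. Any claim that something is new, unique, unknown or untested is made for them only; others in the source may bear on it.

Measured compounds:
Compound 1, `Cc1cc(N2CC[C@@H](C)[C@@H](N(C)c3ncnc4[nH]ccc34)C2)n2ncnc2n1`: 4350 nM
Compound 2, `CCCSc1nc2nc(C)cc(N3CC[C@@H](C)[C@@H](N(C)c4ncnc5[nH]ccc45)C3)n2n1`: 15500 nM
Compound 3, `C[C@@H]1CCN(c2cc(-c3ccccc3)nc3ncnn23)C[C@@H]1N(C)c1ncnc2[nH]ccc12`: 84900 nM

Of the compounds shown here, three built on a shared core have been tested in a functional assay on MGC-803 cells (Homo sapiens) for inhibition, read by MTT assay, with a stated time of 72 h; a higher number here means a weaker inhibitor, a lower number a stronger inhibitor. Compound 1 stands at the lowest number of the three. The nearest to it is compound 2, reached by a 3.6-fold higher number from compound 1 to compound 2 (0.55 log units; beyond the scatter), a modest change that lies beyond the scatter. The furthest is compound 3, reached by a 20-fold higher number from compound 1 to compound 3 (1.29 log units; beyond the scatter), a large change.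

Compound 4, `Cc1cc(N2CC[C@@H](C)[C@@H](N(C)c3ncnc4[nH]ccc34)C2)n2nc(SCC3CC3)nc2n1`, has not yet been measured in this assay. It differs from compound 1 in one place: (cyclopropylmethyl)sulfanyl in place of hydrogen on an aromatic carbon

Among the compounds with values here, the step that bears most directly on this change is the one from compound 1 to compound 2, which likewise attaches a sulfur-linked chain to an aromatic carbon and weakened inhibition by a 3.6-fold higher number from compound 1 to compound 2 (0.55 log units; beyond the scatter). The entering group here is slightly larger and carries a three-membered ring, but the pattern of the change is similar. Compound 4 is therefore expected to show a modest increase in the number, of about a 3.2-fold higher number from compound 1 to compound 4 (0.51 log units; beyond the scatter). The estimated value of compound 4 is 14000 nM, with a plausible range from 5500 nM to 40000 nM.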

Compound 4, half-maximal inhibitory concentration: 9540 nM
Estimate against measurement, compound 4: 1.5-fold (0.17 log units) above, within the range that was stated.
By their numbers in this assay, from the lowest: compound 1; then compounds 4 and 2 (each within the scatter of the next); then compound 3.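

In this assay, the (cyclopropylmethyl)sulfanyl group on the aromatic carbon between two ring nitrogen atoms again gives weaker inhibition than hydrogen (a 2.2-fold higher number from compound 1 to compound 4 (0.34 log units; beyond the scatter)). The propylsulfanyl group of compound 2 and this group therefore point the same way, so the loss seen earlier at this position is no longer tied to one chain, although the pattern rests on these two compounds alone. Cyclopropyl in place of ethyl at the end of the sulfur-linked chain gives a difference that does not stand out from the usual scatter (a 1.6-fold lower number from compound 2 to compound 4 (0.21 log units; within the scatter)), so the two chains cannot be told apart here, and replacing the open end of the chain with a three-membered ring has no readable effect on the number.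

Nothing shown accounts for why either chain weakens inhibition compared with hydrogen, and the link between the change and its cause stays unexplained. As far as these compounds go, it also remains open whether the sulfur itself or the chain it carries drives the step, a question that a methoxy group, an amine or a shorter methylsulfanyl group on the same carbon could address.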